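This account rests on a few compounds, and the source may have more. Where it says the series, first, only, none or still open, it means among the compounds named here.

Compound 1, `CCCCC[Se]c1nc(NCc2ccccc2)c2ccccc2n1`, gives 50 nM in a functional assay on MCF7 cells (Homo sapiens) for cytotoxicity, read by MTT assay, with a stated time of 72 h; a higher number here means a weaker inhibitor of growth, a lower number a stronger inhibitor of growth. Compound 2, `CCCCC[Se]c1nc(N)c2cccnc2n1`, gives 22700 nM in this assay. Compound 3, `C[Se]c1nc(NCc2ccccc2)c2ccccc2n1`, gives 15800 nM in this assay.

Compound 1 and compound 3 share a core and differ only in the chain on the selenium: hydrogen in place of butyl on a saturated chain carbon bound to a selenium atom. That single change brought a 320-fold higher number from compound 1 to compound 3 (2.50 log units; beyond the scatter), a large loss of growth inhibition. Compound 2 carries a different core from compound 1; the difference between the two cores is not broken down here. Compound 2 and compound 3 give numbers within the usual scatter of each other, so no order between them can be read.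

Compound 4, `C[Se]c1nc(N)c2cccnc2n1`, is not yet measured. It stands to compound 2 exactly as compound 3 stands to compound 1, the same change at the same place: hydrogen in place of butyl on a saturated chain carbon bound to a selenium atom. Because the earlier step was a 320-fold higher number from compound 1 to compound 3 (2.50 log units; beyond the scatter), the same shortening is expected to weaken compound 4 by a comparable step from compound 2, estimated at an 8.8-fold higher number from compound 2 to compound 4 (0.95 log units; beyond the scatter), though compound 2 already sits high and the assay may only report a limit. Compound 4 is therefore expected to give about 200000 nM, estimated between 40000 nM and 1000000 nM.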

Compound 4, concentration for 50% growth inhibition: 43000 nM
The estimate for compound 4 lay 4.7-fold (0.67 log units) above the measured number, within the range that was stated.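

On the core of compound 2, putting hydrogen in place of butyl on a saturated chain carbon bound to a selenium atom gave a 1.9-fold higher number from compound 2 to compound 4 (0.28 log units; within the scatter) in this assay, so this pair cannot be put in order. The same change therefore did not have the same effect on the two cores, and its large effect on the core of compound 1 cannot be assumed to carry over to the other core: the same change on two cores in this assay, a 320-fold higher number (2.50 log units; beyond the scatter) from compound 1 to compound 3 and a 1.9-fold higher number (0.28 log units; within the scatter) from compound 2 to compound 4, 170-fold (2.22 log units) apart, beyond the scatter of two such steps

These two pairs do not show which difference between the cores goes with this gap, nor whether the result would hold on any further core. From the compounds shown here alone, what an ethyl or propyl chain, or a longer chain such as heptyl, would give on the selenium of either core remains open. Also open, going by these compounds, is which part of the core of compound 1 must be present for the chain change to produce a large step.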